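From acetamido to 4-chlorophenyl on a double-bonded nitrogen

A few compounds are considered here, and "the series" means these few. Any claim that something is new, unique, unknown or untested is made for them only; others in the source may bear on it.

Among the measured compounds shown here, compound 2 `CC(=O)N/N=C1\C(=O)Nc2ccc(S(=O)(=O)N3CCOCC3)cc21` gives 325000 nM in an ADME assay on WI-38 cells (Homo sapiens) for cytotoxicity, read by sulforhodamine B assay, with a stated time of 24 h (a higher number here means a weaker inhibitor, a lower number a stronger inhibitor), and stands within the scatter of the two other compounds measured so far. Compound 1 `COc1ccc(-c2c(C#N)c(N)n(/N=C3\C(=O)Nc4ccc(S(=O)(=O)N5CCOCC5)cc43)c(=O)c2C#N)cc1` gives 224000 nM and compound 3 `O=C1Nc2ccc(S(=O)(=O)N3CCOCC3)cc2/C1=N/c1ccc(/N=C2\C(=O)Nc3ccc(S(=O)(=O)N4CCOCC4)cc32)cc1` gives 203000 nM in this assay so all three sit in one band.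

Compound 4 `O=C1Nc2ccc(S(=O)(=O)N3CCOCC3)cc2/C1=N/c1ccc(Cl)cc1` carries 4-chlorophenyl in place of acetamido on a double-bonded nitrogen, the difference from compound 2 being 4-chlorophenyl in place of acetamido on a double-bonded nitrogen with the rest of the structure unchanged. For the measured compounds named here, no measured pair isolates a change of this kind, so the expectation rests on little. Compound 3 also holds a six-membered aromatic ring of carbon only on a double-bonded nitrogen and gives 203000 nM without leaving the band. No step beyond the scatter is expected in this assay and any shift should go toward a lower number. The step expected is a 1.5-fold lower number from compound 2 to compound 4 (0.19 log units; within the scatter) and it stays within the scatter. For compound 4 the estimated value is 210000 nM with an expected range from 90000 nM to 400000 nM as the working figure for the coming reading.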

Compound 4, half-maximal inhibitory concentration: 468000 nM
Compound 4: the middle estimate sits 2.2-fold (0.35 log units) below what was measured; measured number above the stated range.
By their numbers in this assay, from the lowest: compounds 3, 1, 2 and 4 (each within the scatter of the next, the first and the last beyond it).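

In this assay, among the compounds shown here, the replacement of acetamido by 4-chlorophenyl on a double-bonded nitrogen gives a 1.4-fold higher number from compound 2 to compound 4 (0.16 log units; within the scatter) and this is the first pair to isolate a single change at this position. The step stays within the scatter even though the entering group brings a six-membered aromatic ring of carbon only and has no hydrogen-bond donor or acceptor, so this pair does not distinguish the two groups at this position. No evidence accompanies this result to explain it.

On these data alone, whether an amine, a carboxylic acid or a longer chain on this nitrogen would also leave the reading within the scatter of compound 2 remains open. As far as these compounds go, this step rests on a single pair, and whether it holds on any other core is also open.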